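The compounds below may be only part of what the source reports. "The series", "measured", "known", "first", "only" and "open" are said of these compounds alone.

Compounds 1 to 4 are close relatives built on one shared core. In an ADME assay on cells (Hepatocyte, Mus musculus) for cytotoxicity, read by MTT assay, with a stated time of 24 h (a lower number here means that less compound is tolerated, a higher number that more compound is tolerated), compound 1 (`Cc1ccc(-c2nn(-c3ccccc3)cc2-c2nc3ccccc3[nH]2)cc1`) gives > 300000 nM, which is a limit of the assay and not a number. Compound 2 (`Cc1ccc(-c2nn(-c3ccccc3)cc2-c2nc3ccccc3n2S(=O)(=O)c2ccccc2)cc1`) gives 189000 nM. Compound 3 (`O=S(=O)(c1ccccc1)n1c(-c2cn(-c3ccccc3)nc2-c2ccc(F)cc2)nc2ccccc21`) gives 231000 nM, so it stands within the scatter of compound 2, and the two cannot be told apart on these numbers.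

Compound 4 (`O=S(=O)(c1ccc(F)cc1)n1c(-c2cn(-c3ccccc3)nc2-c2ccc(F)cc2)nc2ccccc21`) has yet to be measured. It departs from compound 3 by fluoro in place of hydrogen on an aromatic carbon, which turns phenylsulfonyl into (4-fluorophenyl)sulfonyl. Among the measured compounds shown here, no measured step makes exactly this change, but two bear on it. Fluoro in place of methyl on an aromatic carbon gave a 1.2-fold higher number from compound 2 to compound 3 (0.09 log units; within the scatter). Bringing in the phenylsulfonyl group, the part now altered, gave an at least 1.5-fold lower number from compound 1 to compound 2 (0.20 log units; that floor lies within the scatter). Since neither step is shown to go beyond the scatter, no step beyond the scatter is expected in this assay, and neither direction is favoured. The estimate is thus a 1.1-fold lower number from compound 3 to compound 4 (0.03 log units; within the scatter). The expected value for compound 4 is 215000 nM, with an estimated range of 130000 nM to 300000 nM.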

Compound 4, half-maximal cytotoxic concentration: 174000 nM
Beside the measured number, compound 4's estimate is 1.2-fold (0.09 log units) above it; the range from low to high includes it.
By their numbers in this assay, from the lowest: compounds 4, 2 and 3 (each within the scatter of the next). At a limit, above all of these: compound 1.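

The first change made within the phenylsulfonyl group itself, rather than the group being brought in whole, does not move the number beyond the scatter in this assay: fluoro in place of hydrogen, on a six-membered aromatic ring of carbon only and para to a large group, gives a 1.3-fold lower number from compound 3 to compound 4 (0.12 log units; within the scatter). The earlier steps shown here could not show this, since one added the whole group and the other exchanged methyl for fluoro elsewhere on the molecule. Fluoro has now been read in two separate single-place changes, and neither step lies beyond the scatter, so this position tolerates the exchange of hydrogen for fluoro without a readable shift in this one assay.

On these data alone, whether methoxy, an amine or a carboxylic acid at the same place on that ring would give a step beyond the scatter stays open, as does the effect of fluoro elsewhere on the ring. As far as these compounds go, how large the step on bringing in the phenylsulfonyl group truly is also stays open, because compound 1 stands at a limit: the limit of > 300000 nM in this assay, at which 1 of the 4 values shown sits.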